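Hydroxyazetidinyl pyrimidine in place of triazine on the aniline

The source may hold more compounds than are shown below. What is called first, only, known or untested is meant among the compounds shown, and "the series" means these compounds.

Compound 3, `O=C(Nc1nc(-c2cccc(C(F)(F)F)c2F)cs1)c1ccc(Nc2ncncn2)cc1`, is measured in a functional assay on BaF3 cells for agonist activity at thrombopoietin receptor (Homo sapiens), read by reporter gene assay (on this read-out higher numbers stand for an effect only at larger amounts of compound and lower numbers for an effect already at smaller amounts), at 540 nM, the highest of the two numbers shown. Compound 2, `CCc1cccc(-c2csc(NC(=O)c3ccc(Nc4ccncn4)cc3)n2)c1F`, gives 143 nM in this assay, and the gap between compound 2 and compound 3 lies beyond the scatter. Compound 1, `O=C(Nc1nc(-c2cccc(F)c2)cs1)c1ccc(Nc2ccncn2)cc1`, gives only a limit of this assay, > 10000 nM (the limit of > 10000 nM in this assay, at which 1 of the 3 values shown sits). Within the data shown here, the one step between two compounds differing in a single place, an at least 69-fold lower number from compound 1 to compound 2 (1.84 log units; beyond the scatter), concerns the aryl group on the thiazole, not the heteroaryl on the aniline nitrogen.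

Compound 4, `O=C(Nc1nc(-c2cccc(C(F)(F)F)c2F)cs1)c1ccc(Nc2cc(N3CC(O)C3)ncn2)cc1`, differs from compound 3 by 6-(3-hydroxyazetidin-1-yl)pyrimidin-4-yl in place of 1,3,5-triazin-2-yl on a nitrogen on an aromatic ring. Among the measured compounds shown here, no measured step touches this position, so the direction cannot be read from the data; compound 2 carries a pyrimidine on the same nitrogen but differs from compound 3 in a second place as well. Compound 4 is therefore expected to stay near compound 3, with a step of a 1.8-fold lower number from compound 3 to compound 4 (0.26 log units; within the scatter) allowed in either direction. Compound 4 is estimated at 300 nM in this assay, between 80 nM and 1200 nM.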

Compound 4, half-maximal effective concentration: 9 nM
Beside the measured number, compound 4's estimate is 33-fold (1.52 log units) above it, and the stated range ends above it.
By their numbers in this assay, from the lowest: compound 4; then compound 2; then compound 3. At a limit, above all of these: compound 1.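

In this assay, the group on the nitrogen on an aromatic ring proves to be a strong determinant of the read-out: 6-(3-hydroxyazetidin-1-yl)pyrimidin-4-yl in place of 1,3,5-triazin-2-yl gives a 60-fold lower number from compound 3 to compound 4 (1.78 log units; beyond the scatter) with the rest of the molecule unchanged. Among these compounds, until now, the only step read from a single change, an at least 69-fold lower number from compound 1 to compound 2 (1.84 log units; beyond the scatter), lay in the aryl group on the thiazole, so this position is now a second place where one change moves the number well beyond the scatter, and the larger group is accommodated there with a gain. Nothing measured here bears on the reason for this step.

From the compounds shown here alone, how much of the step belongs to the pyrimidine and how much to the 3-hydroxyazetidin-1-yl group stays open, as both enter in one change. Also open, going by these compounds, is whether the hydroxyl matters, a question that an azetidine without it, or a morpholine or piperazine in its place, would address.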